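Fluorophenyl urea regiochemistry and ester-to-amide swap

A few compounds are considered here, and "the series" means these few. Any claim that something is new, unique, unknown or untested is made for them only; others in the source may bear on it.

compound 1 `CCOC(=O)c1cnn2c1N(C(=O)Nc1cccc(F)c1)C(c1ccccc1)C2`: 111 nM
compound 2 `CCOC(=O)c1cnn2c1N(C(=O)Nc1ccc(F)cc1)C(c1ccccc1)C2`: > 1000 nM
compound 3 `NC(=O)c1cnn2c1N(C(=O)Nc1cccc(F)c1)C(c1ccccc1)C2`: 1.2 nM

In a functional assay on cells (Neutrophil, Homo sapiens) for inhibition, with a stated time of 10 min (on this read-out lower numbers stand for stronger inhibition and higher numbers for weaker inhibition), compound 1 gives 111 nM. For compound 2 the assay reports only a limit, > 1000 nM. Compound 3 gives 1.2 nM, the lowest of the two numbers; the step of a 93-fold lower number from compound 1 to compound 3 (1.97 log units; beyond the scatter) goes with amino in place of ethoxy on a carbonyl carbon. The step of an at least 9.0-fold higher number from compound 1 to compound 2 (0.95 log units; beyond the scatter) goes with 4-fluorophenyl in place of 3-fluorophenyl on an amide-type nitrogen, and its size is known only as a bound because the limit of > 1000 nM in this assay, at which 1 of the 3 values shown sits, caps the number.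

Compound 4 `NC(=O)c1cnn2c1N(C(=O)Nc1ccc(F)cc1)C(c1ccccc1)C2` is not yet measured. It differs from compound 3 by 4-fluorophenyl in place of 3-fluorophenyl on an amide-type nitrogen, the same change as from compound 1 to compound 2. The step from compound 3 to compound 4 is expected to be a 13-fold higher number from compound 3 to compound 4 (1.10 log units; beyond the scatter), set beside the earlier one, resting on the loss seen in an at least 9.0-fold higher number from compound 1 to compound 2 (0.95 log units; beyond the scatter). For compound 4 the estimate is 15 nM, between 4 nM and 80 nM.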

Compound 4, half-maximal inhibitory concentration: 484 nM
The estimate for compound 4 lay 32-fold (1.51 log units) below the measured number, and the stated range ends below it.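

In this assay, 4-fluorophenyl in place of 3-fluorophenyl raises the number on both cores, and with the primary amide the step reads a 400-fold higher number from compound 3 to compound 4 (2.61 log units; beyond the scatter), so the direction carries over, but equal or unequal size is not shown: the same change on two cores in this assay, an at least 9.0-fold higher number (0.95 log units; beyond the scatter) from compound 1 to compound 2 and a 400-fold higher number (2.61 log units; beyond the scatter) from compound 3 to compound 4; the limit leaves it open whether they differ
The change of ethoxy to amino lowers the number in both pairs, and with 4-fluorophenyl it reads an at least 2.0-fold lower number from compound 2 to compound 4 (0.31 log units; beyond the scatter): the same change on two cores in this assay, a 93-fold lower number (1.97 log units; beyond the scatter) from compound 1 to compound 3 and an at least 2.0-fold lower number (0.31 log units; beyond the scatter) from compound 2 to compound 4; the limit leaves it open whether they differ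
The value of compound 2, > 1000 nM, is a limit and not a number.

On these data alone, whether 3-chlorophenyl or unsubstituted phenyl on the same nitrogen behaves like 3-fluorophenyl remains open. So does whether a carboxylic acid or an N-methyl amide at the carbonyl carbon would match compound 3.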